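Compound 4 Joins a Small Series in a Cell Toxicity Test

A few compounds are considered here, and "the series" means these few. Any claim that something is new, unique, unknown or untested is made for them only; others in the source may bear on it.

Three related compounds have so far been tested in an ADME assay on LNCaP cells (Homo sapiens) for cytotoxicity; a lower number here means that less compound is needed, a higher number that more compound is needed for the effect. Compound 1 `CC1=C(C=O)C[C@@H]2[C@@](C)(CCC3=CC(=O)OC3O)[C@H](C)CC[C@@]12C` gives 4.5 ug/mL, compound 2 `CC1=CCC[C@@H]2[C@@](C)(/C=C/C3=CC(=O)O[C@H]3O)[C@H](C)CC[C@@]12C` gives 2.5 ug/mL, and compound 3 `CC1=CCC[C@@H]2[C@@](C)(C[C@H](O)C3=CCOC3=O)[C@H](C)CC[C@@]12C` gives 3.3 ug/mL. Compound 3 stands second highest of the three, but its gaps to compound 2 and to compound 1 both lie within the usual scatter, so the three cannot be ranked against each other. Compound 4 `CC1=CCC[C@@H]2[C@@](C)(C[C@H](O)C3=CC(=O)O[C@H]3O)[C@H](C)CC[C@@]12C` is not yet measured. It differs from compound 3 in one place: a group of 7 heavy atoms (4 carbon, 3 oxygen; one five-membered non-aromatic ring with 1 hetero atom) in place of a group of 6 heavy atoms (4 carbon, 2 oxygen; one five-membered non-aromatic ring with 1 hetero atom), on a saturated chain carbon bound to an oxygen on a saturated carbon and a saturated chain carbon. Compound 2 already carries the entering ring and gives 2.5 ug/mL, close to compound 3. The step of a 1.1-fold lower number from compound 3 to compound 4 (0.04 log units; within the scatter) is therefore expected to stay within the scatter. Compound 4 is estimated at 3 ug/mL, within a range from 1.2 ug/mL to 7.5 ug/mL.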

Compound 4, concentration for half-maximal effect: 4.1 ug/mL
Compound 4: middle estimate off by 1.4-fold (0.14 log units), on the low side; measured number inside the range.
By their numbers in this assay, from the lowest: compounds 2, 3, 4 and 1 (each within the scatter of the next).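

In this assay, exchanging the group on this saturated chain carbon gives a 1.2-fold higher number from compound 3 to compound 4 (0.09 log units; within the scatter). Within the data shown here, this is the first comparison that differs in one place only, and it shows that the entering ring, with its extra oxygen and hydrogen-bond donor, leaves the number within the scatter of the ring it replaces. Nothing measured here gives a reason for this result.

From the compounds shown here alone, whether an amine or a carboxylic acid in place of the ring would shift the number remains open. So does whether a longer chain at this place would do so.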